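Taking the octyl group off compound 2

This account rests on a few compounds, and the source may have more. Where it says the series, first, only, none or still open, it means among the compounds named here.

Compound 1 `CCCCCCCCCCCCC/C=C/C(=O)[C@H](CO)NC(C)=O` and compound 2 `CCCCCCCCc1ccc(/C=C/C(=O)[C@H](CO)NC(C)=O)cc1` have both been tested in a functional assay on HepG2 cells (Homo sapiens) for antiproliferative activity, read by resazurin assay, with a stated time of 24 h; a lower number here means a stronger inhibitor, a higher number a weaker inhibitor. In this assay compound 1 gives 175000 nM, while compound 2 gives 65000 nM. Compound 2 therefore holds the lower of the two numbers, and the gap lies beyond the usual scatter, making it the stronger inhibitor of this pair.

The next compound to be tested is compound 3 `CC(=O)N[C@@H](CO)C(=O)/C=C/c1ccccc1`. It differs from compound 2 in a single place: hydrogen in place of octyl on an aromatic carbon. In words, hydrogen stands in place of octyl on an aromatic carbon, para to a large group.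

Within the data shown here, no measured pair shows this kind of change on its own, so the forecast rests on little evidence. Among the measured compounds shown here, with only two values available, a modest loss of activity seems the more likely direction, though a step beyond the scatter is far from certain. The expected change in this assay is estimated as a 2.3-fold higher number from compound 2 to compound 3 (0.36 log units; beyond the scatter). For compound 3 the expected value is 150000 nM, with an estimated range of 60000 nM to 400000 nM.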

Compound 3, half-maximal inhibitory concentration: > 200000 nM
Compound 3: only a limit was reported (the forecaster's own chance of this, stated with the estimate: 30%); at least 1.3-fold (0.12 log units) between middle value and limit.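

Among these compounds, replacing octyl with hydrogen on an aromatic carbon, para to a large group, gives the first measured step at this position: in this assay, the change is an at least 3.0-fold higher number from compound 2 to compound 3 (0.48 log units; beyond the scatter). Compound 3 gives > 200000 nM, which is a limit of the assay and not a number. The octyl group therefore matters for the activity of compound 2 at this position, but the printed step is only a minimum, and the full size of the loss stays unknown because compound 3 has no exact value: the limit of > 200000 nM in this assay, at which 1 of the 3 values shown sits.

The compounds shown hold only the two extremes at this aromatic carbon, hydrogen and octyl, so they leave open whether a butyl chain would keep part of the activity of compound 2 or a dodecyl chain would improve on it. They also leave open whether a carbon chain is needed here at all, which an amine or a carboxylic acid on the same aromatic carbon could help to show.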